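The compounds below may be only part of what the source reports. "The series", "measured", "known", "first", "only" and "open" are said of these compounds alone.

Working notes on the series. The shared core of compound 1 `CCCCn1nc(-c2cccnc2)c2ccccc2c1=O` carries a propyl chain on the aromatic nitrogen; in an assay on isolated protein (Oryctolagus cuniculus) with Thromboxane-A synthase (Homo sapiens) as the target, tested at 1 uM (on this read-out lower numbers stand for less inhibition and higher numbers for more inhibition at the one concentration tested (going by the name of the read-out)), compound 1 gives 91%. Compound 2 `CCOC(=O)Cn1nc(-c2cccnc2)c2ccccc2c1=O` differs from it in one place, and in this assay compound 2 gives 28%. Within the data shown here, the only step measured so far is the one between them: a number 63 percentage points lower from compound 1 to compound 2 (beyond the scatter). Among the measured compounds shown here, compound 2 therefore stands lowest of the two numbers, with compound 1 as its only neighbour at the higher figure.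

Compound 3 `O=C(c1cccs1)n1nc(-c2cccnc2)c2ccccc2c1=O` has not been measured. Its change from compound 2 is (thiophen-2-yl)carbonyl in place of (ethoxycarbonyl)methyl on an aromatic nitrogen. For the measured compounds named here, no measured step bears directly on this change: the single known step, from compound 1 to compound 2, exchanges one chain for another on the same nitrogen and was large, but nothing shows how a (thiophen-2-yl)carbonyl group behaves in that place. The expectation is therefore a step of a number 22 percentage points higher from compound 2 to compound 3 (beyond the scatter) upward from compound 2, held with wide uncertainty. Compound 3 is estimated at 50%, expected between 20% and 85% in this assay.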

Compound 3, a percentage reported as inhibition, at one concentration (the size of the read-out at that concentration, not a potency): 37%
Compound 3: the middle estimate sits 13 percentage points above what was measured, and the stated range covers the measured number.
By their numbers in this assay, from the lowest: compounds 2 and 3 (each within the scatter of the next); then compound 1.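

In this assay, (thiophen-2-yl)carbonyl in place of (ethoxycarbonyl)methyl on the aromatic nitrogen gives a number 9 percentage points higher from compound 2 to compound 3 (within the scatter) on this read-out, so a five-membered aromatic ring with sulfur entering at this place does not separate these two compounds. (Thiophen-2-yl)carbonyl in place of butyl gives a number 54 percentage points lower from compound 1 to compound 3 (beyond the scatter) as a large step, which shows that the large step seen earlier is not confined to the group carrying the ethyl ester: two different groups on this nitrogen now stand far from compound 1 on the same read-out. No measurement on hand explains either step.

Both entering groups carry a carbonyl, and the three compounds cannot tell whether that carbonyl or the loss of the plain alkyl chain goes with the lower figures. Open too, going by these compounds, is how a longer alkyl chain, a benzyl group, an amine-bearing chain or a carboxylic acid in place of the ethyl ester would stand on this nitrogen.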